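This account rests on a few compounds, and the source may have more. Where it says the series, first, only, none or still open, it means among the compounds named here.

Measured compounds in an ADME assay on MT4 cells (Homo sapiens) for cytotoxicity, read by MTT assay, with a stated time of 96 h; on this read-out higher numbers stand for lower toxicity in this test and lower numbers for higher toxicity in this test:
Compound 1 `COc1ccc(-c2nc3cc(/C(C)=N/O)ccc3[nH]2)c(OC)c1` gives >= 100000 nM, which is a limit of the assay.
Compound 2 `COc1ccc(-c2nc3cc(/C(C)=N/O)ccc3[nH]2)c(OC)c1OC` gives 51000 nM.
Compound 3 `COc1ccc(-c2nc3cc(/C(C)=N/NC(N)=O)ccc3[nH]2)cc1` gives "not determined" (no result reported).

From compound 1 to compound 2 the change is methoxy in place of hydrogen on an aromatic carbon, and it made an at least 1.9-fold lower number from compound 1 to compound 2 (0.29 log units; that floor lies within the scatter); that step starts from the limit of >= 100000 nM in this assay, at which 1 of the 3 values shown sits. Compound 4 `COc1ccc(-c2nc3cc(/C(C)=N/NC(N)=O)ccc3[nH]2)c(OC)c1` is not yet measured. From compound 3 to compound 4 the change is methoxy in place of hydrogen on an aromatic carbon. This is the same kind of change as the earlier one, though the surroundings differ: in compound 2 the entering methoxy is ortho to two methoxy groups and meta to a large group, while in compound 4 it is ortho to a large group and meta to a methoxy group. How the core of compound 3 differs from that of compound 1 is not broken down here. Among the measured compounds shown here, compound 3 has no number in this assay, so the expectation for compound 4 rests on the one measured step, an at least 1.9-fold lower number from compound 1 to compound 2 (0.29 log units; that floor lies within the scatter), which sets only a floor. Compound 4 is expected to give about 80000 nM in this assay, estimated to fall between 30000 nM and 200000 nM.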

Compound 4, half-maximal cytotoxic concentration: 21000 nM
The estimate for compound 4 lay 3.8-fold (0.58 log units) above the measured number; the whole stated range lies above it.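

In this assay compound 3 has no result, so the step from it to compound 4 cannot be read and the methoxy change cannot be compared between the two cores. What can be read is ureido in place of hydroxy on a double-bonded nitrogen, which gave an at least 4.7-fold lower number from compound 1 to compound 4 (0.67 log units; beyond the scatter). That size is only a floor, and it does not show how methoxy behaves on either core, as the step starts from a limit of the assay: the limit of >= 100000 nM in this assay, at which 1 of the 4 values shown sits.

The compounds shown leave open how an amine or a carboxylic acid in place of ureido on the double-bonded nitrogen would read. They also leave open what ethoxy in place of the entering methoxy would give.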